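The source may hold more compounds than are shown below. What is called first, only, known or untested is meant among the compounds shown, and "the series" means these compounds.

Values in a functional assay on KB cells (Homo sapiens) for cytotoxicity, read by sulforhodamine B assay; a higher number here means a weaker inhibitor, a lower number a stronger inhibitor:
- Compound 1 `C=C1[C@@H](OC(C)=O)C[C@@H]2[C@](C)(CO[Si](C)(C)C(C)(C)C)[C@H](OC(C)=O)CC[C@@]2(C)[C@@H]1C[C@@H](Nc1cccc(F)c1)C1=CCOC1=O`: 4560 nM
- Compound 2 `C=C1[C@@H](OC(C)=O)C[C@@H]2[C@](C)(CO[Si](C)(C)C(C)(C)C)[C@H](OC(C)=O)CC[C@@]2(C)[C@@H]1C[C@@H](Nc1ccc(O)cc1)C1=CCOC1=O`: 8350 nM
- Compound 3 `C=C1[C@@H](OC(C)=O)C[C@@H]2[C@](C)(CO[Si](C)(C)C(C)(C)C)[C@H](OC(C)=O)CC[C@@]2(C)[C@@H]1C[C@@H](Nc1ccc(C(=O)O)cc1)C1=CCOC1=O`: 5540 nM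

Compound 3 stands within the scatter of both other compounds, so the three values show no order. Compound 4 `C=C1[C@@H](OC(C)=O)C[C@@H]2[C@](C)(CO[Si](C)(C)C(C)(C)C)[C@H](OC(C)=O)CC[C@@]2(C)[C@@H]1C[C@@H](Nc1cccc(OC)c1)C1=CCOC1=O` carries 3-methoxyphenyl in place of 4-carboxyphenyl on an amine nitrogen. Three measured steps change the group at this same nitrogen, and all of them are small: a 1.8-fold higher number from compound 1 to compound 2 (0.26 log units; within the scatter), a 1.2-fold higher number from compound 1 to compound 3 (0.08 log units; within the scatter) and a 1.5-fold lower number from compound 2 to compound 3 (0.18 log units; within the scatter). None of these compounds carries a methoxy group, so the evidence is indirect. No shift beyond the scatter is therefore expected in this assay, and the estimated step is a 1.1-fold lower number from compound 3 to compound 4 (0.03 log units; within the scatter). For compound 4 the estimated value is 5200 nM, with an expected range of 2900 nM to 9300 nM.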

Compound 4, half-maximal inhibitory concentration: 45200 nM
Compound 4: middle estimate off by 8.7-fold (0.94 log units), on the low side; the measured number lies above the stated range.
By their numbers in this assay, from the lowest: compounds 1, 3 and 2 (each within the scatter of the next); then compound 4.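

In this assay the group on the amine nitrogen can matter after all: 3-methoxyphenyl brings an 8.2-fold higher number from compound 3 to compound 4 (0.91 log units; beyond the scatter) and a 5.4-fold higher number from compound 2 to compound 4 (0.73 log units; beyond the scatter) and also a 9.9-fold higher number from compound 1 to compound 4 (1.00 log units; beyond the scatter) and so leaves compound 4 the weakest of the four, although the three earlier groups stayed within the scatter of one another. That last step is only methoxy in place of fluoro on an aromatic carbon, and this one change is enough to pass the scatter. Nothing given here accounts for the shift. Going by these compounds, it remains open whether an ethoxy or an amino group in place of the methoxy would give the same rise, and whether the weakening belongs to the methoxy group itself.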